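Swapping fluoro for trifluoromethyl in two related anticonvulsant amides

The compounds below may be only part of what the source reports. "The series", "measured", "known", "first", "only" and "open" are said of these compounds alone.

Compound 1 `CC(C(=O)NCc1cccc(F)c1)N1C(=O)CCC1=O` and compound 2 `CC(C(=O)NCc1cccc(C(F)(F)F)c1)N1C(=O)CCC1=O` share one core, and compound 3 `CCC(C(=O)NCc1ccccc1F)N1C(=O)CCC1=O` and compound 4 `CCC(C(=O)NCc1ccccc1C(F)(F)F)N1C(=O)CCC1=O` share another; the difference between the two cores is not broken down here. In a functional assay on the whole organism (strain Albino Swiss CD1) with Mus musculus as the target, in the maximal electroshock model (on this read-out lower numbers stand for an effect already at smaller amounts and higher numbers for an effect only at larger amounts of compound), compound 1 gives 77.4 mg/kg and compound 2 gives 92.4 mg/kg. In this assay compound 3 gives "not determined" (no result reported), so no number was obtained for it. The change from compound 1 to compound 2 is trifluoromethyl in place of fluoro on an aromatic carbon, and from compound 3 to compound 4 it is trifluoromethyl in place of fluoro on an aromatic carbon; the surroundings differ, since one sits meta to a large group and the other ortho to a large group, so these are the same kind of change, not the same. That earlier step was a 1.2-fold higher number from compound 1 to compound 2 (0.08 log units; within the scatter). Compound 4 is therefore expected to give about 90 mg/kg, between 40 mg/kg and 200 mg/kg, because the related step of a 1.2-fold higher number from compound 1 to compound 2 (0.08 log units; within the scatter) stayed small.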

Compound 4, dose for half-maximal effect: > 150 mg/kg
Compound 4: no number, only a limit; the forecaster's own chance of this, stated with the estimate: 15%; middle value at least 1.6-fold (0.22 log units) away from the limit.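

Among the compounds shown here, compound 3 has no number in this assay, so no step from it to compound 4 can be read. Compound 4 gives > 150 mg/kg, which is a limit and not a number. The compounds shown leave open how far trifluoromethyl in place of fluoro shifts the dose on the core of compound 3.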